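Shortening the Ether Side Chain of Compound 2

The compounds below may be only part of what the source reports. "The series", "measured", "known", "first", "only" and "open" are said of these compounds alone.

Within the data shown here, compound 2 `O=C(/C=C/c1ccc(O)cc1)c1c(O)cccc1OCCC1CCCC1` is the one member of this small set with a definite number: in a functional assay on PC-3 cells (Homo sapiens) for antiproliferative activity, read by sulforhodamine B assay (a higher number here means a weaker inhibitor of growth, a lower number a stronger inhibitor of growth), compound 2 gives 3480 nM. Compound 1 `COc1cccc(OCCC(C)(C)C)c1C(=O)/C=C/c1ccc(O)cc1` reaches only a limit of the assay, > 30000 nM, in this assay. Compound 3 `CC(C)(C)CCOc1cccc(O)c1C(=O)CCc1ccc(O)cc1` likewise stops at a limit, > 30000 nM, in this assay. Two of the three values shown therefore sit at the limit of > 30000 nM in this assay, at which 2 of the 3 values shown sit, and compound 2 alone offers a measured point to start from.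

Compound 4 `CC(C)COc1cccc(O)c1C(=O)/C=C/c1ccc(O)cc1` differs from compound 2 in one place: isopropyl in place of cyclopentylmethyl on a saturated chain carbon bound to an oxygen on an aromatic ring. Among the measured compounds shown here, no pair of measured compounds here differs in a single place, so there is no measured step that tells how large such a change is. For the measured compounds named here, with compound 2 at 3480 nM as the only number, and compound 1 and compound 3 both resting at the limit of > 30000 nM in this assay, at which 2 of the 3 values shown sit, a weakening is the more likely direction, of a size expected to exceed the usual scatter. Compound 4 is therefore estimated at 9000 nM, with a range from 2500 nM to 30000 nM. The expected step of a 2.6-fold higher number from compound 2 to compound 4 (0.41 log units; beyond the scatter) reflects that loss of growth inhibition.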

Compound 4, concentration for 50% growth inhibition: 2970 nM
Compound 4: the middle estimate sits 3.0-fold (0.48 log units) above what was measured; the range from low to high includes it.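

Among these compounds, for the first time, a single change can be read in this assay: isopropyl in place of cyclopentylmethyl on a saturated chain carbon bound to an oxygen on an aromatic ring gives a 1.2-fold lower number from compound 2 to compound 4 (0.07 log units; within the scatter). For this pair, then, the five-membered carbon ring is not needed to keep the growth inhibition, and the open-chain isopropyl group serves just as well on the same core. No measurement shown here offers a reason for so small a step.

Going by these compounds, it remains open whether other groups at this place would behave the same way: an unbranched hexyl chain, a longer chain ending in a phenyl ring, or a chain ending in an amine or a carboxylic acid could each move the number in either direction. It is also open whether this swap would give so small a step with the rest of the molecule changed, for no second pair carrying the same swap appears among the compounds shown.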